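A few compounds are considered here, and "the series" means these few. Any claim that something is new, unique, unknown or untested is made for them only; others in the source may bear on it.

Working notes on the series.

Compound 1 `Cc1ccc2nc(C(=O)Nc3c(F)cc(-c4cccc(F)c4)cc3F)c(C)c(O)c2c1` and compound 2 `CCOc1ccc2nc(C(=O)Nc3c(F)cc(-c4cccc(F)c4)cc3F)c(C)c(O)c2c1` share one core and differ only at one aromatic carbon of the fused two-ring part. In a functional assay on A-375 cells (Homo sapiens) for antiproliferative activity, read by MTT assay, with a stated time of 24 h, tested at 100 ug/mL (a higher number here means a stronger effect of the compound at the concentration tested, a lower number a weaker effect), compound 1 gives 56.4%, and compound 2 gives 37.9%. Going by the values given here, the single step available, a number 18.5 percentage points lower from compound 1 to compound 2 (beyond the scatter), shows that the group at this position moves the read-out. Among the compounds with values here, on the two numbers so far compound 2 stands lowest, with compound 1 as its only neighbour and higher by more than the scatter.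

Compound 3 `Cc1c(C(=O)Nc2c(F)cc(-c3cccc(F)c3)cc2F)nc2ccc(C(F)(F)F)cc2c1O` is the next member at this same position. Its change from compound 2: trifluoromethyl in place of ethoxy on an aromatic carbon. Within the data shown here, no measured pair covers an ethoxy-to-trifluoromethyl exchange, so the only bearing evidence is the step from compound 1 to compound 2, which was modest. Since a change at this position has been seen to move the read-out by a modest amount, a step of similar magnitude, in either direction, is expected, and the estimate leans toward a partial return toward the level of compound 1, giving a number 9.1 percentage points higher from compound 2 to compound 3 (within the scatter) as the expected step. Compound 3 is therefore estimated at 47%, with a range from 30% to 64%.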

Compound 3, a percentage reported as inhibition, at one concentration (the size of the read-out at that concentration, not a potency): 95.2%
For compound 3 the middle estimate is 48.2 percentage points below the measured one; measured number above the stated range.
By their numbers in this assay, from the lowest: compound 2; then compound 1; then compound 3.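

In this assay the exchange of ethoxy for trifluoromethyl gives a number 57.3 percentage points higher from compound 2 to compound 3 (beyond the scatter) and the exchange of methyl for trifluoromethyl gives a number 38.8 percentage points higher from compound 1 to compound 3 (beyond the scatter) as the second large step, so this position can move the read-out much further than the first pair showed, and upward as well as downward. Compound 3 stands above both compound 1 and compound 2 by more than the scatter, giving the order ethoxy, methyl, trifluoromethyl across these three compounds only. No measured evidence is available to account for this order.

The three compounds leave open whether the high read-out belongs to trifluoromethyl alone or extends to other groups at this position, such as a chlorine atom, a nitrile, an amine or a carboxylic acid, or whether a longer chain such as propoxy continues the drop seen with ethoxy. They also leave open whether the order holds at lower concentrations, since each value is the size of the read-out at one concentration and not a potency.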